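The source may report more compounds than this note shows. Statements on the series, on what has been measured and on what is new or still open speak of the compounds shown alone.

Measured so far in a functional assay on HFF cells (Homo sapiens) for inhibition; a lower number here means a stronger inhibitor, a higher number a weaker inhibitor:
- compound 1 `Cc1nsc2[nH]c(SCc3ccccc3)nc12`: 10000 nM
- compound 2 `Cc1nsc2c1nc(SCc1ccccc1)n2[C@H]1C[C@H](O)[C@@H](CO)O1`: for compound 2 the value reported is a limit of the assay, > 100000 nM
- compound 3 `OC[C@H]1O[C@@H](n2c(SCc3ccccc3)nc3cnsc32)C[C@@H]1O`: for compound 3 the value is likewise a limit of the assay, > 100000 nM

Compound 2 therefore stands at the ceiling of what this assay can report, the same place where compound 3 sits; this is the limit at which two of the three values gather (the limit of > 100000 nM in this assay, at which 2 of the 3 values shown sit). For the measured compounds named here, only one step has a readable size: an at least 10-fold higher number from compound 1 to compound 2 (1.00 log units; beyond the scatter), which shows that attaching the sugar-like ring to the aromatic nitrogen of the shared core pushed the number up to the limit. The other step, a step that the two limits leave unreadable from compound 2 to compound 3, cannot be sized, since both of its values are limits.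

Compound 4 `Cc1nsc2c1nc(SCc1ccccc1)n2[C@@H]1O[C@H](CO)[C@@H](O)[C@@H]1O` differs from compound 2 by hydroxy in place of hydrogen on a saturated ring carbon. Going by the values given here, no measured step concerns a change on the saturated ring itself, so there is nothing in the numbers that would argue for a move back below the limit. The expectation is that compound 4 stays where compound 2 stands, with a step of a number no higher from compound 2 to compound 4 (the limit leaves the size open). Compound 4 is estimated at 100000 nM, with a range from 30000 nM to 300000 nM.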

Compound 4, half-maximal inhibitory concentration: > 100000 nM
Compound 4 was reported as a limit; the forecaster's own chance of this, stated with the estimate: 80%; the middle value sits exactly at the limit.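

Compound 4 is reported only as a limit of the assay, > 100000 nM, and compound 2 is also a limit, so no step can be read between compound 2 and compound 4. Both sit at the same ceiling: the limit of > 100000 nM in this assay, at which 3 of the 4 values shown sit.

Going by these compounds, what stays open is whether hydroxy in place of hydrogen on the saturated ring carbon changes the number at all in this assay.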